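Replacing 4-chlorophenyl with propylamino on compound 1

A few compounds are considered here, and "the series" means these few. Any claim that something is new, unique, unknown or untested is made for them only; others in the source may bear on it.

compound 1 (`CN1CCC(C(=O)N2Cc3c(NC(=O)c4ccc(Cl)cc4)n[nH]c3C2(C)C)CC1`): 120 nM
compound 2 (`CN1CCN(C(=O)N2Cc3c(NC(=O)c4ccc(F)cc4)n[nH]c3C2(C)C)CC1`): 180 nM
compound 3 (`CC(C)(C)C(=O)N1Cc2c(NC(=O)c3ccncc3)n[nH]c2C1(C)C`): 110 nM

In a functional assay on A2780 cells (Homo sapiens) for antiproliferative activity, read by fluorescence, with a stated time of 72 h (on this read-out lower numbers stand for stronger inhibition and higher numbers for weaker inhibition), compound 1 lies within the scatter of both compound 3 and compound 2, so the three values do not separate. Compound 4 (`CCCNC(=O)Nc1n[nH]c2c1CN(C(=O)C1CCN(C)CC1)C2(C)C`) carries propylamino in place of 4-chlorophenyl on a carbonyl carbon. Within the data shown here, no measured pair isolates this change. Compound 1 (120 nM), compound 2 (180 nM) and compound 3 (110 nM) all hold an aromatic ring on that carbonyl carbon, and compound 4 holds none. A move to a higher number, beyond the scatter, is expected in this assay and is estimated as a 3.3-fold higher number from compound 1 to compound 4 (0.52 log units; beyond the scatter) on this basis alone. Compound 4 is estimated at 400 nM in a range from 120 nM to 1400 nM pending measurement.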

Compound 4, half-maximal inhibitory concentration: 650 nM
Compound 4: middle estimate off by 1.6-fold (0.21 log units), on the low side, within the range that was stated.
By their numbers in this assay, from the lowest: compounds 3, 1 and 2 (each within the scatter of the next); then compound 4.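

With propylamino in place of 4-chlorophenyl on a carbonyl carbon, this assay shows a 5.4-fold higher number from compound 1 to compound 4 (0.73 log units; beyond the scatter), the only single-place step among the compounds shown. Among these compounds, this position is therefore sensitive to this change, which the earlier compounds, all carrying an aromatic ring there, could not show. Nothing measured here bears on the cause of the step.

Still open, going by these compounds, is whether the step follows from losing the aromatic ring or from the entering nitrogen. A butyl chain or a benzylamino group on the same carbonyl carbon would separate the two.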